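The source may report more compounds than this note shows. Statements on the series, on what has been measured and on what is new or still open speak of the compounds shown alone.

Measured so far:
Compound 1 `NC(=O)N1CCN(C(=S)SCc2cn(Cc3ccc(F)cc3)nn2)CC1` — in a functional assay on MCF7 cells (Homo sapiens) for cytotoxicity, read by MTT assay, with a stated time of 72 h (a lower number here means a stronger inhibitor, a higher number a weaker inhibitor), compound 1 gives 22100 nM.
Compound 2 `CCNC(=O)N1CCN(C(=S)SCc2cn(Cc3ccc(F)cc3)nn2)CC1` — compound 2 gives 3660 nM.
Compound 3 `CCN(C)C(=O)N1CCN(C(=S)SCc2cn(Cc3ccc(F)cc3)nn2)CC1` — compound 3 gives 2150 nM.

Compound 3 has the lowest of the three numbers, but its gap to compound 2 is within the scatter a 1.7-fold lower number from compound 2 to compound 3 (0.23 log units; within the scatter), so the two cannot be ranked; only compound 1 stands clearly apart a 10-fold lower number from compound 1 to compound 3 (1.01 log units; beyond the scatter).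

Compound 4 `CCN(C)C(=O)N1CCN(C(=S)SCc2cn(Cc3ccc(C)cc3)nn2)CC1` differs from compound 3 by methyl in place of fluoro on an aromatic carbon. Within the data shown here, all three measured steps change the urea end of the shared core a 6.0-fold lower number from compound 1 to compound 2 (0.78 log units; beyond the scatter), none touch the aromatic ring, so no measured step bears directly on this change. Compound 4 is therefore expected to stay close to compound 3, with a step of a 1.2-fold higher number from compound 3 to compound 4 (0.07 log units; within the scatter) inside the scatter, giving an estimate of 2500 nM for compound 4, in the range 900 nM to 7000 nM.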

Compound 4, half-maximal inhibitory concentration: 40100 nM
Estimate against measurement, compound 4: 16-fold (1.21 log units) below; measured number outside the range, above it.
By their numbers in this assay, from the lowest: compounds 3 and 2 (each within the scatter of the next); then compounds 1 and 4 (each within the scatter of the next).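

Moving from 4-fluorobenzyl to 4-methylbenzyl in this assay gives a 19-fold higher number from compound 3 to compound 4 (1.27 log units; beyond the scatter). So this aromatic position is far from silent: exchanging one heavy atom here shifts the number about as much as the earlier change at the urea end, a 10-fold lower number from compound 1 to compound 3 (1.01 log units; beyond the scatter). No available measurement explains this change.

As far as these compounds go, whether fluoro is the favourable group or methyl the unfavourable one stays open, and chloro, methoxy or plain hydrogen at this position would help separate the two. Also open, from the compounds shown here alone, is whether the same exchange gives a similar step with other urea ends.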